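The source may report more compounds than this note shows. Statements on the series, on what has been measured and on what is new or still open speak of the compounds shown alone.

Measured so far:
compound 1 `COc1ccc(/C=C/C(=O)c2sc(Nc3ccc(Cl)cc3)nc2C)cc1`, which in a functional assay on Bel-7402 cells (Homo sapiens) for cytotoxicity, read by MTT assay (a lower number here means a stronger inhibitor, a higher number a weaker inhibitor), gives > 25000 nM, a limit of the assay
compound 2 `Cc1nc(Nc2ccc(Cl)c(Cl)c2)sc1C(=O)/C=C/c1ccccc1`, which in this assay gives 21500 nM
compound 3 `Cc1nc(Nc2ccc(Cl)c(Cl)c2)sc1C(=O)/C=C/c1ccc(Cl)cc1`, which in this assay gives > 25000 nM, again a limit of the assay

Compound 3 therefore stands at the limit of this assay rather than at a number, and the limit of > 25000 nM in this assay, at which 2 of the 3 values shown sit, shows that one further compound sits there too. Only compound 2 yields a figure, and the step of an at least 1.1-fold higher number from compound 2 to compound 3 (0.06 log units; that floor lies within the scatter), chloro in place of hydrogen on an aromatic carbon, lies within the scatter at its floor.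

Compound 4 is `COc1ccc(/C=C/C(=O)c2sc(Nc3ccc(Cl)c(Cl)c3)nc2C)cc1`. It differs from compound 3 by methoxy in place of chloro on an aromatic carbon. Among the compounds with values here, no measured step covers a methoxy replacing a chloro, so the one measured step bears on the change only through its starting point, compound 3. Within the data shown here, compound 1, which carries the same methoxy on a core that differs elsewhere, gives a limit in this assay; between compound 1 and compound 4 no step is given, so its limit can only be noted.

Compound 4 is expected to remain at the limit, with an estimated step that the limit leaves unreadable from compound 3 to compound 4 that cannot be told from the scatter. The estimate for compound 4 in this assay is 30000 nM, between 10000 nM and 100000 nM.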

Compound 4, half-maximal inhibitory concentration: > 25000 nM
Compound 4 gave a limit, no number; the forecaster's own chance of this, stated with the estimate: 80%; the middle value is on the limit's open side.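

The position para to a large group now carries a second substituent, methoxy, and with it, as with chloro, the compound gives only a limit in this assay, not a number. Within the data shown here, measured from the one compound with a figure, adding methoxy gives an at least 1.1-fold higher number from compound 2 to compound 4 (0.06 log units; that floor lies within the scatter), so this change, like the chloro one before it, shows no shift that can be told from the scatter at its floor. The steps into compound 4 from compound 3 and from compound 1 cannot be read, and the compounds now sit largely at one edge of the measurable range: the limit of > 25000 nM in this assay, at which 3 of the 4 values shown sit.

How far any of these compounds lies past the limit stays open, so it cannot be said whether methoxy and chloro differ at this position. Also open, as far as these compounds go, is whether an amine, a hydroxyl or a carboxylic acid on this aromatic carbon would give a number clear of the limit and so make the position readable.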